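Trading phenylsulfanyl for methylsulfonyl on the side chain

The compounds below may be only part of what the source reports. "The series", "measured", "known", "first", "only" and "open" are said of these compounds alone.

In a functional assay on PC-3 cells (Homo sapiens) for antiproliferative activity, read by MTT assay, with a stated time of 24 h (on this read-out lower numbers stand for stronger inhibition and higher numbers for weaker inhibition), compound 3 (`CCN(CC)CCNC(=O)c1cc(C(CC)(CC)c2ccc(OCSc3ccccc3)c(C)c2)cn1CC`) gives 2620 nM and sits within the scatter of compound 1 (`CCN(CC)CCNC(=O)c1ccc(C(CC)(CC)c2ccc(OCSc3ccccc3)c(C)c2)n1CC`) at 2230 nM while compound 2 (`CCN(CC)CCNC(=O)c1cc(C(CC)(CC)c2ccc(OCSC)c(C)c2)cn1CC`) reads clearly higher at 9540 nM on the same scale. Compound 4 (`CCN(CC)CCNC(=O)c1cc(C(CC)(CC)c2ccc(OCS(C)(=O)=O)c(C)c2)cn1CC`) differs from compound 3 in one place (methylsulfonyl in place of phenylsulfanyl on a saturated chain carbon bound to an oxygen on an aromatic ring) and so no longer carries the phenyl ring. Within the data shown here, the one measured step that bears on this is a 3.6-fold lower number from compound 2 to compound 3 (0.56 log units; beyond the scatter) when phenyl replaced methyl on a sulfur, modest but beyond the scatter. Among the measured compounds shown here, compound 4 goes back from phenyl to methyl, so a modest move to a higher number is expected, though no measured compound carries methylsulfonyl. The expected step is a 3.6-fold higher number from compound 3 to compound 4 (0.56 log units; beyond the scatter) in this estimate. Compound 4 is estimated at 9500 nM within a range of 4500 nM to 22000 nM for now.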

Compound 4, half-maximal inhibitory concentration: 36600 nM
Beside the measured number, compound 4's estimate is 3.9-fold (0.59 log units) below it; the whole stated range lies below it.
By their numbers in this assay, from the lowest: compounds 1 and 3 (each within the scatter of the next); then compound 2; then compound 4.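

Among these compounds, the earlier compounds showed only that the group on the sulfur matters; this result shows that adding oxygens to the sulfur matters too. With the methyl kept, methylsulfonyl in place of methylsulfanyl gives a 3.8-fold higher number from compound 2 to compound 4 (0.58 log units; beyond the scatter) and the full exchange for phenylsulfanyl gives a 14-fold higher number from compound 3 to compound 4 (1.15 log units; beyond the scatter) at this same place, so losing the phenyl ring and gaining the oxygens both go with higher numbers. Nothing available explains either change. Still open, from the compounds shown here alone, is how phenylsulfonyl, which keeps the phenyl ring and carries the two oxygens, would read against compound 3 and compound 4.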